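The source may report more compounds than this note shows. Statements on the series, on what has been measured and on what is new or still open speak of the compounds shown alone.

Compound 1 `CC(=O)Oc1ccc2oc(/C=C/[S+](C)[O-])cc(=O)c2c1`, compound 2 `CCCC(=O)Oc1ccc2oc(/C=C/[S+](C)[O-])cc(=O)c2c1` and compound 3 `CCCOc1ccc2oc(/C=C/[S+](C)[O-])cc(=O)c2c1` share one core. In a functional assay on DLD-1 cells (Homo sapiens) for cytotoxicity, with a stated time of 48 h (a higher number here means a weaker inhibitor, a lower number a stronger inhibitor), compound 2 gives 8700 nM and compound 3 gives 6200 nM. Compound 1 reaches only (the limit of > 10000 nM in this assay, at which 1 of the 3 values shown sits), a limit of this assay rather than a number, so compound 1 gives > 10000 nM. The change hydrogen in place of ethyl on a saturated chain carbon bound to a carbonyl carbon made a step of an at least 1.1-fold higher number from compound 2 to compound 1 (0.06 log units; that floor lies within the scatter). The cores of compound 2 and compound 3 differ by propyl in place of propylcarbonyl on an oxygen on an aromatic ring, a step of a 1.4-fold lower number from compound 2 to compound 3 (0.15 log units; within the scatter). Compound 4 `COc1ccc2oc(/C=C/[S+](C)[O-])cc(=O)c2c1`, not yet measured, differs from compound 3 by hydrogen in place of ethyl on a saturated chain carbon bound to an oxygen on an aromatic ring; this is the same kind of change as between compound 2 and compound 1, but its place is a saturated chain carbon bound to an oxygen on an aromatic ring, not one bound to a carbonyl carbon. Since compound 2 and compound 1 gave an at least 1.1-fold higher number from compound 2 to compound 1 (0.06 log units; that floor lies within the scatter), the expected step is a 1.3-fold higher number from compound 3 to compound 4 (0.11 log units; within the scatter). Compound 4 is therefore estimated at 8000 nM, between 4000 nM and 20000 nM.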

Compound 4, half-maximal inhibitory concentration: 5700 nM
Beside the measured number, compound 4's estimate is 1.4-fold (0.15 log units) above it, within the range that was stated.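

In this assay, the swaps on the oxygen on the aromatic ring give a 1.1-fold lower number from compound 3 to compound 4 (0.04 log units; within the scatter), a 1.5-fold lower number from compound 2 to compound 4 (0.18 log units; within the scatter) and an at least 1.7-fold lower number from compound 1 to compound 4 (0.24 log units; that floor lies within the scatter). Placed side by side, the two steps for hydrogen in place of ethyl do not establish either a shared effect or a difference between the cores: the same change on two cores in this assay, an at least 1.1-fold higher number (0.06 log units; that floor lies within the scatter) from compound 2 to compound 1 and a 1.1-fold lower number (0.04 log units; within the scatter) from compound 3 to compound 4; the limit leaves it open whether they differ Compound 1 has only a limit of the assay rather than a number, so this pair cannot show whether the change carries over unaltered from one core to the other: the limit of > 10000 nM in this assay, at which 1 of the 4 values shown sits.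

The compounds shown leave open what a longer chain, an amine or a carboxylic acid would do on this oxygen. They also leave open whether any group placed there would give a step beyond the scatter.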